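A few compounds are considered here, and "the series" means these few. Any claim that something is new, unique, unknown or untested is made for them only; others in the source may bear on it.

Compound 1 `C=CC1=C(C(=O)NCCC)C(c2ccc(F)cc2)OC1` – > 100000 nM
Compound 2 `C=CC1=C(C(=O)NCC(C)C)C(c2ccc(F)cc2)OC1` – > 100000 nM
Compound 3 `C=CC1=C(C(=O)Nc2ccccc2)C(c2ccc(F)cc2)OC1` – > 100000 nM

The three compounds share one core and differ only in the group carried on the amide nitrogen. In a functional assay on HeLa cells (Homo sapiens) for cytotoxicity, read by MTT assay, with a stated time of 24 h (on this read-out higher numbers stand for weaker inhibition and lower numbers for stronger inhibition), compound 1 gives > 100000 nM, which is a limit of the assay and not a measured number. Compound 2 gives > 100000 nM, again a limit. Compound 3 gives > 100000 nM, once more a limit. Compound 3 thus stands at the same limit as the other two, as the limit of > 100000 nM in this assay, at which 3 of the 3 values shown sit, records, and no measured number sets it apart. For the same reason the steps a step that the two limits leave unreadable from compound 1 to compound 2, a step that the two limits leave unreadable from compound 1 to compound 3 and a step that the two limits leave unreadable from compound 2 to compound 3 cannot be given a size or a direction.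

Compound 4 `C=CC1=C(C(=O)Nc2cccc(C)c2)C(c2ccc(F)cc2)OC1` is the next compound to be measured. Compared with compound 3 its change is methyl in place of hydrogen on an aromatic carbon. For the measured compounds named here, none of the measured steps bears readably on such a change, since every value so far sits at the limit, so nothing in these data points to a step beyond the scatter in either direction. Compound 4 is therefore expected to give 150000 nM, with a range from 40000 nM to 600000 nM, most probably reported again only as a limit. The expected step from compound 3 to compound 4 is a step that the limit leaves unreadable from compound 3 to compound 4, that is, no change beyond the scatter.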

Compound 4, half-maximal inhibitory concentration: "not active" (no number reported)
The entry for compound 4 holds no number; there is nothing to compare the estimate with.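

For the compounds shown here, the entry for compound 4 in this assay reads "not active" and gives no number, so no step from compound 3 to compound 4 can be read. The compounds shown leave open whether any group on the amide nitrogen would give a measured value, and the record offers only a limit: the limit of > 100000 nM in this assay, at which 3 of the 4 values shown sit.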